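Replacing 4-aminophenyl with furan-2-yl on a carbonyl carbon

The source may report more compounds than this note shows. Statements on the series, on what has been measured and on what is new or still open speak of the compounds shown alone.

Of the compounds shown here, three sharing one core have been tested in a functional assay on L5178Y cells (Mus musculus) for inhibition, read by MTT assay, with a stated time of 24 h; on this read-out higher numbers stand for weaker inhibition and lower numbers for stronger inhibition. Compound 1 (`COc1cc(O)c2c(c1)O[C@H](c1ccc(O)cc1)C/C2=N\N`) gives >= 11300 nM, which is a limit and not a number. Compound 2 (`COc1cc(O)c2c(c1)O[C@H](c1ccc(O)cc1)C/C2=N\NC(=O)c1cccs1`) gives a true number, 9400 nM. Compound 3 (`COc1cc(O)c2c(c1)O[C@H](c1ccc(O)cc1)C/C2=N\NC(=O)c1ccc(N)cc1`) gives >= 11300 nM, which is also a limit. Compound 3 thus stands at the limit of >= 11300 nM in this assay, at which 2 of the 3 values shown sit.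

The next structure, compound 4 (`COc1cc(O)c2c(c1)O[C@H](c1ccc(O)cc1)C/C2=N\NC(=O)c1ccco1`), carries furan-2-yl in place of 4-aminophenyl on a carbonyl carbon. For the measured compounds named here, two measured steps bear on this change. Acylation of the amine nitrogen with (thiophen-2-yl)carbonyl gave an at least 1.2-fold lower number from compound 1 to compound 2 (0.07 log units; that floor lies within the scatter). Exchanging thiophen-2-yl for 4-aminophenyl on the carbonyl carbon gave an at least 1.2-fold higher number from compound 2 to compound 3 (0.07 log units; that floor lies within the scatter). The step that the two limits leave unreadable from compound 1 to compound 3 adds nothing on size. With no measured step shown beyond the scatter, no step beyond the scatter is expected in this assay. The expected step is an at least 1.1-fold lower number from compound 3 to compound 4 (0.05 log units; that floor lies within the scatter). Compound 4 is estimated at 10000 nM, within an expected range of 5500 nM to 17000 nM.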

Compound 4, half-maximal inhibitory concentration: >= 11300 nM
Compound 4 ended at the assay's limit; the forecaster's own chance of this, stated with the estimate: 45%; at least 1.1-fold (0.05 log units) between middle value and limit.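

In this assay, the change from thiophen-2-yl to furan-2-yl on the carbonyl carbon gives an at least 1.2-fold higher number from compound 2 to compound 4 (0.07 log units; that floor lies within the scatter), so only a floor is known and it shows no real difference between these two five-membered aromatic rings. The steps to compound 4 from compound 1 and from compound 3 cannot be read, as both ends of each are limits. Among the three acylated compounds, only compound 2, with thiophen-2-yl, gives a true number, and the set now gathers at one point: the limit of >= 11300 nM in this assay, at which 3 of the 4 values shown sit.

From the compounds shown here alone, how far compound 1, compound 3 and compound 4 lie past that limit stays open, so these groups cannot be ranked against each other. Also open, going by these compounds, is whether a non-aromatic group on the carbonyl carbon, such as methyl or a longer alkyl chain, would give a true number.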